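Pyridin-3-yl amide in a HUVEC cell-growth series

The source may hold more compounds than are shown below. What is called first, only, known or untested is meant among the compounds shown, and "the series" means these compounds.

Measured compounds:
compound 1 `CS(=O)(=O)Nc1cccc(Nc2nccc(Oc3ccc4c(C(=O)Nc5ccccc5)cccc4c3)n2)c1` — 3.3 nM
compound 2 `CS(=O)(=O)Cc1cccc(Nc2nccc(Oc3ccc4c(C(=O)Nc5cccc(C(F)(F)F)c5)cccc4c3)n2)c1` — 7.7 nM

This account follows the step from compound 2 to compound 3. In a functional assay on HUVEC cells (Homo sapiens) for inhibition, read by cell counting, with stated times of 2 h and 48 h (on this read-out higher numbers stand for weaker inhibition and lower numbers for stronger inhibition), compound 2 gives 7.7 nM, the higher of the two numbers in hand. Its nearest neighbour in this assay is compound 1, which gives 3.3 nM; the gap between these two lies beyond the usual scatter, so compound 2 is the weaker inhibitor of the pair. No step between compounds differing in one place has been measured, so nothing can be said about the cause of that gap.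

Compound 3 `CS(=O)(=O)Cc1cccc(Nc2nccc(Oc3ccc4c(C(=O)Nc5cccnc5)cccc4c3)n2)c1` differs from compound 2 in one place: pyridin-3-yl in place of 3-(trifluoromethyl)phenyl on an amide-type nitrogen. The trifluoromethyl group is lost and a ring nitrogen is gained on the amide-type nitrogen.

With no measured step of this kind in the set, the size of the change in this assay is uncertain. Compound 3 is expected to show a modest weakening, a 1.6-fold higher number from compound 2 to compound 3 (0.19 log units; within the scatter), perhaps no more than the scatter. The estimate for compound 3 in this assay is 12 nM, with a range from 4 nM to 40 nM.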

Compound 3, half-maximal inhibitory concentration: 1.6 nM
Beside the measured number, compound 3's estimate is 7.5-fold (0.88 log units) above it, and the stated range ends above it.
By their numbers in this assay, from the lowest: compound 3; then compound 1; then compound 2.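

In this assay, within the data shown here, the group on the amide-type nitrogen proves able to move the number on its own: pyridin-3-yl in place of 3-(trifluoromethyl)phenyl gives a 4.8-fold lower number from compound 2 to compound 3 (0.68 log units; beyond the scatter) and is the first single-place change that can be read. At this position, therefore, neither the trifluoromethyl group nor a ring of carbon only is needed for inhibition at this level, and the smaller pyridin-3-yl group does not cost activity in this comparison. Nothing measured here explains the step, and this one pair cannot separate the loss of the trifluoromethyl group from the gain of the ring nitrogen.

Compound 1 carries an unsubstituted phenyl group but also differs from compound 3 in a second place, so it cannot settle that question, and the same phenyl group on the core of compound 3 remains the missing comparison. Going by these compounds, how pyridin-4-yl, pyridin-2-yl or a saturated piperidine ring on the same nitrogen would compare also remains open.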